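The source may report more compounds than this note shows. Statements on the series, on what has been measured and on what is new or still open speak of the compounds shown alone.

Measured in a functional assay on ECa-109 cells (Homo sapiens) for cytotoxicity, read by MTT assay, with a stated time of 72 h; a lower number here means a stronger inhibitor, a higher number a weaker inhibitor:
- Compound 1 `Cc1cc(N2CCCCC2)nc(SCc2nc3ccccc3[nH]2)n1`: > 100000 nM, a limit
- Compound 2 `Cc1cc(N2CCNCC2)nc(SCc2nc3ccccc3[nH]2)n1`: > 100000 nM, a limit

Compound 2 therefore stands only at a limit, with no number to place it. All the evidence so far is the limit of > 100000 nM in this assay, at which 2 of the 2 values shown sit. Compound 3 `Cc1ccc(Nc2cc(C)nc(SCc3nc4ccccc4[nH]3)n2)cc1` carries (4-methylphenyl)amino in place of piperazin-1-yl on an aromatic carbon. Among the compounds with values here, the sole measured step, a step that the two limits leave unreadable from compound 1 to compound 2, offers no size to carry over. Only a weak expectation follows, of a modest move towards stronger inhibition in this assay, or none. The expected change is an at least 2.0-fold lower number from compound 2 to compound 3 (0.30 log units; that floor lies within the scatter). For compound 3 the estimate is 50000 nM, with an expected range from 10000 nM to 200000 nM.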

Compound 3, half-maximal inhibitory concentration: 57300 nM
Estimate against measurement, compound 3: 1.1-fold (0.06 log units) below; the range from low to high includes it.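

Compound 3 gives this position its first reading in this assay that is a number and not a limit. Placing (4-methylphenyl)amino here gives an at least 1.7-fold lower number from compound 2 to compound 3 (0.24 log units; that floor lies within the scatter), and the same group set against piperidin-1-yl gives an at least 1.7-fold lower number from compound 1 to compound 3 (0.24 log units; that floor lies within the scatter); each step has only a floor, and the step between compound 1 and compound 2 cannot be read. From the compounds shown here alone, the true size of both steps stays open. So does the part played by the methyl group, which plain phenylamino or benzylamino on this carbon would address.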